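Swapping 3-aminophenyl in a sulfanyl series

This account rests on a few compounds, and the source may have more. Where it says the series, first, only, none or still open, it means among the compounds named here.

Compound 1 `COc1cc2c(cc1OC)C(c1cccc(N)c1)=NN=C(S)C2` gives 18.8 umol/kg
Compound 2 `COc1cc2c(cc1OC)C(c1ccc(Br)cc1)=NNC(=O)C2` gives 110 umol/kg
Compound 3 `COc1cc2c(cc1OC)C(c1ccc(Br)cc1)=NN(C)C(=S)C2` gives 105 umol/kg

All three values come from a functional assay on the whole organism with Mus musculus as the target; on this read-out lower numbers stand for an effect already at smaller amounts and higher numbers for an effect only at larger amounts of compound. Compound 1 has the lowest of the three numbers, and its gaps to compound 2 and to compound 3 both lie beyond the usual scatter. Compound 2 and compound 3 lie within the scatter of each other.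

The next compound to be measured is compound 4 `COc1cc2c(cc1OC)C(c1ccc(Cl)cc1)=NN=C(S)C2`, which has 4-chlorophenyl in place of 3-aminophenyl on a carbon with a double bond to nitrogen. The sulfanyl group of compound 1 stays.

Among the measured compounds shown here, no measured pair isolates this change, so the expectation rests on little. Of the measured compounds, only compound 1 carries 3-aminophenyl, while compound 2 at 110 umol/kg and compound 3 at 105 umol/kg do not, and both show higher numbers. On that basis, a moderate step to a higher number in this assay is expected, probably beyond the scatter, and the expected size is a 3.7-fold higher number from compound 1 to compound 4 (0.57 log units; beyond the scatter). For compound 4 the estimated value is 70 umol/kg, with an expected range from 28 umol/kg to 170 umol/kg.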

Compound 4, dose for half-maximal effect: 82.4 umol/kg
Estimate against measurement, compound 4: 1.2-fold (0.07 log units) below; the range from low to high includes it.
By their numbers in this assay, from the lowest: compound 1; then compounds 4, 3 and 2 (each within the scatter of the next).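

In this assay, among the compounds shown here, the swap of 3-aminophenyl for 4-chlorophenyl on the carbon with a double bond to nitrogen gives a 4.4-fold higher number from compound 1 to compound 4 (0.64 log units; beyond the scatter) with the sulfanyl group and the rest of the core unchanged, and this is the first comparison that isolates this position. The sulfanyl group alone therefore does not secure the low number of compound 1, since compound 4 keeps that group and still gives 82.4 umol/kg in this assay, so the group at this position matters to the read-out in this pair. Nothing available on these compounds accounts for the step.

For the compounds shown here, the single pair changes two things at once, the substituent on the phenyl ring and where it sits, so it cannot show whether the amine, its ring place or both go with the lower number of compound 1. Going by these compounds, that question stays open for 3-chlorophenyl, 4-aminophenyl and unsubstituted phenyl at this position on the same sulfanyl core, and also for an acetamide in place of the amine on the 3-aminophenyl ring.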